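The source may hold more compounds than are shown below. What is called first, only, known or untested is meant among the compounds shown, and "the series" means these compounds.

Measured so far:
compound 1 `CC(C)N(Cc1ccc(C(=O)NO)cc1)S(=O)(=O)c1c(F)c(F)c(F)c(F)c1F` — 440 nM
compound 2 `CC(C)N(Cc1ccc(C(=O)NO)cc1)Cc1cc(F)c(F)c(F)c1F` — 11400 nM
compound 3 `CC(C)N(Cc1ccc(C(=O)NO)cn1)S(=O)(=O)c1cc(F)c(F)c(F)c1F` — 1600 nM

In a functional assay on MM1.S cells (Homo sapiens) for inhibition, with a stated time of 72 h (a higher number here means a weaker inhibitor, a lower number a stronger inhibitor), compound 1 has the lowest number of the three; the nearest is compound 3, and the gap to compound 3 lies beyond the scatter, as does the wider gap to compound 2. No pair among these three differs in one place only, so no single step is counted here. Compound 4 `CC(C)N(Cc1ccc(C(=O)NO)cc1)S(=O)(=O)c1cc(F)c(F)c(F)c1F` is not yet measured. It differs from compound 1 as follows: hydrogen in place of fluoro on an aromatic carbon. Among the compounds with values here, with no counted step to lean on, a modest move toward a higher number is expected, of a size a 1.8-fold higher number from compound 1 to compound 4 (0.26 log units; within the scatter), though a change within the scatter would not surprise. For compound 4 in this assay the estimated value is 800 nM, ranging from 300 nM to 2500 nM.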

Compound 4, half-maximal inhibitory concentration: 1380 nM
Compound 4: middle estimate off by 1.7-fold (0.24 log units), on the low side; the range from low to high includes it.
By their numbers in this assay, from the lowest: compound 1; then compounds 4 and 3 (each within the scatter of the next); then compound 2.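

Hydrogen in place of fluoro on this aromatic carbon gives, in this assay, a 3.1-fold higher number from compound 1 to compound 4 (0.50 log units; beyond the scatter). Within the data shown here, this is the first change in one place only, and it shows that this single position, ortho to a large group and para to a fluoro group, shifts the number beyond the scatter on its own. Nothing on hand explains the step.

On these data alone, whether a chloro, methyl or methoxy group on this carbon would hold the number of compound 1 stays open. Also open, as far as these compounds go, is whether removing fluoro at the other ring positions gives a step of similar size.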